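Swapping the Amine on Two Related Cores

A few compounds are considered here, and "the series" means these few. Any claim that something is new, unique, unknown or untested is made for them only; others in the source may bear on it.

Compound 1 `CCNCC(=O)Nc1cc(OC)ccc1C(=O)c1ccc2c(c1)C=CC(C)(C)O2` and compound 2 `COc1ccc(C(=O)c2ccc3c(c2)C=CC(C)(C)O3)c(NC(=O)CN(C)C)c1` share one core and differ at a single point: dimethylamino in place of ethylamino on a saturated chain carbon bound to a carbonyl carbon. In a functional assay on MCF7 cells (Homo sapiens) for antiproliferative activity, read by MTT assay, with a stated time of 48 h (on this read-out higher numbers stand for weaker inhibition and lower numbers for stronger inhibition), compound 1 gives 6310 nM, and compound 2 gives 3560 nM; the step is a 1.8-fold lower number from compound 1 to compound 2 (0.25 log units; within the scatter). Compound 3 `C=C(c1ccc(OC)cc1NC(=O)CNCC)c1ccc(OC)c2c1OC(C)(C)C=C2` carries the ethylamino group on a second core, and the difference between the two cores is not broken down here. In this assay compound 3 gives 2100 nM; its gap to compound 2 is within the scatter, while its gap to compound 1 lies beyond it. Compound 4 `C=C(c1ccc(OC)cc1NC(=O)CN(C)C)c1ccc(OC)c2c1OC(C)(C)C=C2` is not yet measured and differs from compound 3 by the same change, at the same place: dimethylamino in place of ethylamino on a saturated chain carbon bound to a carbonyl carbon. In this assay the step from compound 3 to compound 4 is expected to be a 1.4-fold lower number from compound 3 to compound 4 (0.15 log units; within the scatter), beside a 1.8-fold lower number from compound 1 to compound 2 (0.25 log units; within the scatter) on the first core; this expectation rests on that earlier step being within the scatter, so little movement is expected here either. Compound 4 is estimated at 1500 nM, most likely between 600 nM and 3500 nM.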

Compound 4, half-maximal inhibitory concentration: 500 nM
For compound 4 the middle estimate is 3.0-fold (0.48 log units) above the measured one; the measured number lies below the stated range.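

In this assay, putting dimethylamino in place of ethylamino on the second core gives a 4.2-fold lower number from compound 3 to compound 4 (0.62 log units; beyond the scatter), a step large enough to stand clear of the usual variation between repeated measurements, which the same swap on the first core did not do. Set side by side, the two steps point the same way and cannot be told apart in size: the same change on two cores in this assay, a 1.8-fold lower number (0.25 log units; within the scatter) from compound 1 to compound 2 and a 4.2-fold lower number (0.62 log units; beyond the scatter) from compound 3 to compound 4, 2.4-fold (0.37 log units) apart, within the scatter of two such steps

So the swap carried over in direction on these two cores, but a single pair on each core makes no general rule, and these results do not show that the second core responds more strongly or explain why the numbers fall.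

The compounds shown leave open how a diethylamino group, or a ring amine such as pyrrolidine or morpholine, would behave at this place on either core. They also leave open what a longer chain carrying the dimethylamino group would do to the number in this assay.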